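Phenyl for hydroxy on a sulfonylindole core

The compounds below may be only part of what the source reports. "The series", "measured", "known", "first", "only" and "open" are said of these compounds alone.

Compound 1 `O=S(=O)(c1ccccc1)n1ccc2c(O)cccc21`: 108 nM
Compound 2 `COc1ccc2c(ccn2S(=O)(=O)c2ccccc2)c1`: 127 nM
Compound 3 `CC(=O)N1CCN(c2cn(S(=O)(=O)c3ccccc3)c3ccccc23)CC1`: 97 nM

Of the compounds shown here, three sharing an arylsulfonyl core have been measured in an assay on isolated protein for displacement of a labelled ligand from 5-hydroxytryptamine receptor 6 (Homo sapiens), read by scintillation counting, with a stated time of 1 h; on this read-out lower numbers stand for stronger inhibition and higher numbers for weaker inhibition. Compound 1 gives 108 nM, compound 2 gives 127 nM and compound 3 gives 97 nM; compound 1 sits among the other two, and none of the three differs from another by more than the usual scatter. Compound 4 `O=S(=O)(c1ccccc1)n1ccc2c(-c3ccccc3)cccc21` is not yet measured. It differs from compound 1 in one place: phenyl in place of hydroxy on an aromatic carbon. Among the compounds with values here, no pair of measured compounds shows this kind of exchange, so there is no measured step to lean on. A step of modest size, if any, is expected from compound 1 to compound 4, a 1.5-fold higher number from compound 1 to compound 4 (0.17 log units; within the scatter), with a slight drift toward weaker binding. For compound 4 the expected value in this assay is 160 nM, with a range from 40 nM to 650 nM.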

Compound 4, inhibition constant: 162 nM
Beside the measured number, compound 4's estimate is 1.0-fold (0.01 log units) below it, and the stated range covers the measured number.
By their numbers in this assay, from the lowest: compounds 3, 1, 2 and 4 (each within the scatter of the next).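

In this assay the exchange of hydroxy for phenyl on this aromatic carbon gives a 1.5-fold higher number from compound 1 to compound 4 (0.18 log units; within the scatter) and so shows that the position accepts a much larger group, a whole six-membered aromatic ring, without a change beyond the scatter. The hydrogen-bond donor and acceptor of the hydroxy are gone in compound 4, yet the number stays within the scatter of compound 1. No measurement shown here offers an explanation for this. As far as these compounds go, whether an amine, a carboxylic acid or a longer chain on this carbon would read the same remains open, as does the effect of substituents on the phenyl.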